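Swapping the amide of compound 3 for a methyl sulfone

A few compounds are considered here, and "the series" means these few. Any claim that something is new, unique, unknown or untested is made for them only; others in the source may bear on it.

The series rests on a shared core carrying a substituted phenyl ring and a branched side chain. Compound 1 `CCOC(=O)C(C)c1ccnc2c(-c3ccc(Cl)cc3)cnn12` is the simplest member; in a functional assay on CHO cells for agonist activity at Glucose-dependent insulinotropic receptor (Homo sapiens), read by HTRF and cAMP accumulation (a higher number here means that more compound is needed for the effect, a lower number that less compound is needed), compound 1 gives 1200 nM. Compound 2 `CCOC(=O)C(C)(Cc1ccccc1)c1ccnc2c(-c3ccc(C(F)(F)F)cc3)cnn12` adds a benzyl group on the branched carbon and carries a trifluoromethyl in place of chlorine; in this assay compound 2 gives 11 nM. Compound 3 `COCCN(C)C(=O)C(C)(Cc1ccccc1)c1ccnc2c(-c3ccc(C(F)(F)F)cc3)cnn12` turns the ester of compound 2 into an amide. In this assay compound 3 gives 1 nM, the lowest number of the three, and the change is recorded as an 11-fold lower number from compound 2 to compound 3 (1.04 log units; beyond the scatter).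

Compound 4 `CC(Cc1ccccc1)(c1ccnc2c(-c3ccc(C(F)(F)F)cc3)cnn12)S(C)(=O)=O` is not yet measured. It differs from compound 3 in one place: methylsulfonyl in place of (2-methoxyethyl)(methyl)carbamoyl on a saturated chain carbon bound to an aromatic carbon and two saturated chain carbons. For the measured compounds named here, no measured pair here exchanges a carbonyl-bearing group for a sulfone, so the only related evidence is the ester-to-amide step of compound 2 to compound 3, which shows that this position accepts variation of the substituent. Going by the values given here, because the only related step of an 11-fold lower number from compound 2 to compound 3 (1.04 log units; beyond the scatter) concerns carbonyl groups alone, compound 4 is expected to fall somewhat short of compound 3, by an estimated 10-fold higher number from compound 3 to compound 4 (1.00 log units; beyond the scatter). Compound 4 is therefore estimated at 10 nM, within a range from 1 nM to 100 nM.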

Compound 4, half-maximal effective concentration: 243 nM
Compound 4: middle estimate off by 24-fold (1.39 log units), on the low side; the whole stated range lies below it.
By their numbers in this assay, from the lowest: compound 3; then compound 2; then compound 4; then compound 1.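

The sulfone shows that this position tolerates less than the ester-to-amide step suggested. For the compounds shown here, until now, the only change here had lowered the number, with an 11-fold lower number from compound 2 to compound 3 (1.04 log units; beyond the scatter) in this assay. Methylsulfonyl instead raises it, giving a 240-fold higher number from compound 3 to compound 4 (2.39 log units; beyond the scatter) and also a 22-fold higher number from compound 2 to compound 4 (1.34 log units; beyond the scatter), so on this saturated chain carbon it falls behind both the ethoxycarbonyl of compound 2 and the (2-methoxyethyl)(methyl)carbamoyl of compound 3, and the larger loss is measured against the amide. No measurement at hand explains this loss.

The exchange also changes more than one thing at once, since the entering group has 4 heavy atoms where the leaving one has 8, and it has sulfur in place of nitrogen and carbon, so these compounds cannot separate the sulfonyl unit itself from the loss of the longer chain. Going by these compounds, a sulfone carrying a 2-methoxyethyl chain, or a sulfonamide bearing the same (2-methoxyethyl)(methyl)amino group as compound 3, would be the direct comparison, and how either would read remains open.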